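A few compounds are considered here, and "the series" means these few. Any claim that something is new, unique, unknown or untested is made for them only; others in the source may bear on it.

Measured in an in vivo functional assay on the whole organism for inhibition of 3-hydroxy-3-methylglutaryl-coenzyme A reductase (Rattus norvegicus), at a dose of 0.2 mg/kg by the oral route; a lower number here means a weaker effect, a higher number a stronger effect of the compound at the dose given:
compound 1 `CCc1c(C)sc2nc(C(C)C)c(/C=C/[C@@H](O)C[C@@H](O)CC(=O)O)c(-c3ccc(F)cc3)c12` gives 7.9%
compound 2 `Cc1nn(Cc2ccccc2)c2nc(C(C)C)c(/C=C/[C@@H](O)C[C@@H](O)CC(=O)O)c(-c3ccc(F)cc3)c12` gives 16.4%
compound 3 `CC(C)c1cc2c(-c3ccc(F)cc3)c(/C=C/[C@@H](O)C[C@@H](O)CC(=O)O)c(C(C)C)nc2s1` gives -71.5%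

Compound 2 has the highest number of the three in this assay. Its gap to compound 1 lies within the scatter, so no order between these two can be read from the numbers; its gap to compound 3 lies beyond the scatter. Compound 4 `Cc1nn(C)c2nc(C(C)C)c(/C=C/[C@@H](O)C[C@@H](O)CC(=O)O)c(-c3ccc(F)cc3)c12` is not yet measured. It differs from compound 2 as follows: hydrogen in place of phenyl on a saturated chain carbon bound to an aromatic nitrogen. For the measured compounds named here, no pair of measured compounds shows this change, so its size cannot be taken from the numbers at hand; the step from compound 2 to compound 4 in this assay is expected to be small, in neither direction beyond the scatter. Compound 4 is therefore estimated to give 12% in this assay, with a range from -8% to 30%. The expected step is a number 4.4 percentage points lower from compound 2 to compound 4 (within the scatter).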

Compound 4, a percentage reported as inhibition, in the whole organism at one dose (the size of the read-out at that dose, not a potency): 41.1%
Compound 4: the middle estimate sits 29.1 percentage points below what was measured, outside the stated range (above it).
By their numbers in this assay, from the lowest: compound 3; then compounds 1 and 2 (each within the scatter of the next); then compound 4.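

In this assay, hydrogen in place of phenyl on a saturated chain carbon bound to an aromatic nitrogen, read also as benzyl to methyl, gives a number 24.7 percentage points higher from compound 2 to compound 4 (beyond the scatter). This position is therefore sensitive to the change, and the phenyl is not required for an effect at the dose given. No measurement at hand bears on the reason for this step. Only benzyl and methyl are shown at this place, so the outcome with ethyl, a longer chain such as butyl, or a chain ending in an amine stays open.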